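The compounds below may be only part of what the source reports. "The series", "measured", "known", "first", "only" and "open" are said of these compounds alone.

Compound 3 `COc1ccc(CN2C(=O)C(=O)c3cc(-c4ccc(F)cc4)ccc32)cc1` carries a 4-fluorophenyl group on the shared core. In a functional assay on HepG2 cells (Homo sapiens) for antiproliferative activity, read by MTT assay, with a stated time of 48 h (a higher number here means a weaker inhibitor, a lower number a stronger inhibitor), compound 3 gives 3150 nM, the highest of the two numbers measured here. Compound 1 `COc1ccc(CN2C(=O)C(=O)c3cc(-c4cc(OC)cc(OC)c4)ccc32)cc1`, with a 3,5-dimethoxyphenyl group in that place, gives 1200 nM in this assay, and the step of a 2.6-fold higher number from compound 1 to compound 3 (0.42 log units; beyond the scatter) lies beyond the scatter. Compound 2 `COc1ccc(CN2C(=O)C(=O)c3cc(-c4ccc(OC)c(OC)c4)ccc32)cc1` reaches only a limit of this assay, > 10000 nM. The step of an at least 3.1-fold lower number from compound 2 to compound 3 (0.50 log units; beyond the scatter) runs the other way, and an at least 8.3-fold higher number from compound 1 to compound 2 (0.92 log units; beyond the scatter) shows the widest shift among the measured pairs.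

Compound 4 `COc1ccc(CN2C(=O)C(=O)c3cc(-c4ccc(C)cc4)ccc32)cc1` differs from compound 3 by methyl in place of fluoro on an aromatic carbon. Among the measured compounds shown here, none of the measured steps exchanges a single substituent on that ring; each replaces the whole pendant aryl group, and those swaps came out modest or at least modest. The account therefore expects the step of a 1.1-fold lower number from compound 3 to compound 4 (0.02 log units; within the scatter) to be no larger than modest, with no clear direction. Compound 4 is estimated at 3000 nM in this assay, with a range from 1200 nM to 8000 nM.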

Compound 4, half-maximal inhibitory concentration: > 10000 nM
Compound 4 ended at the assay's limit; the forecaster's own chance of this, stated with the estimate: 10%; at least 3.3-fold (0.52 log units) between middle value and limit.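

The earlier steps shown here each replaced the whole pendant aryl group, whereas this one exchanges a single substituent on that ring, and in this assay the step of an at least 3.1-fold higher number from compound 3 to compound 4 (0.50 log units; beyond the scatter) shows that methyl in place of fluoro is enough to move the result beyond the scatter. Set against the 3,5-dimethoxyphenyl group, the 4-methylphenyl group gives the step of an at least 8.3-fold higher number from compound 1 to compound 4 (0.92 log units; beyond the scatter), so this small exchange reaches the same limit as the larger swap to 3,4-dimethoxyphenyl. The result for compound 4 is a limit and not a number, and the step from 3,4-dimethoxyphenyl to 4-methylphenyl cannot be read: the limit of > 10000 nM in this assay, at which 2 of the 4 values shown sit.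

As far as these compounds go, how a chlorine atom, a methoxy group or an amine in this same place would compare with fluoro and methyl remains open. From the compounds shown here alone, whether the contrast between fluoro and methyl holds on other substitution patterns of that ring also stays open.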